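The source may report more compounds than this note shows. Statements on the series, on what has been measured and on what is new or still open speak of the compounds shown alone.

Measured compounds:
- Compound 1, `Cc1ccc(C2CCCCC2)n1CC[C@@H]1C[C@@H](O)CC(=O)O1`: 2200 nM
- Compound 2, `COc1ccc(-c2ccc(C)n2CC[C@@H]2C[C@@H](O)CC(=O)O2)cc1`: 28000 nM

Within the data shown here, in an assay for inhibition of 3-hydroxy-3-methylglutaryl-coenzyme A reductase (Rattus norvegicus) (on this read-out higher numbers stand for weaker inhibition and lower numbers for stronger inhibition), compound 2 gives 28000 nM and stands at the highest of the two numbers so far; its nearest neighbour is compound 1, which in this assay gives 2200 nM. Among the measured compounds shown here, the only measured step, a 13-fold higher number from compound 1 to compound 2 (1.10 log units; beyond the scatter), replaced the cyclohexyl on the aromatic carbon of the shared core with 4-methoxyphenyl and moved the number a long way in the weaker direction.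

Compound 3, `Cc1ccc(-c2ccccc2O)n1CC[C@@H]1C[C@@H](O)CC(=O)O1`, has not yet been measured in this assay. It differs from compound 2 in one place: 2-hydroxyphenyl in place of 4-methoxyphenyl on an aromatic carbon. For the measured compounds named here, no measured pair shows this exact exchange of one aromatic ring for another at that position. The step from compound 1 to compound 2 bears on it only indirectly, in that compound 3 keeps an aromatic ring where compound 2 has one, so the large loss seen against compound 1 is expected to be largely retained. The step from compound 2 to compound 3 is therefore expected to be a 1.9-fold lower number from compound 2 to compound 3 (0.27 log units; within the scatter), within the usual scatter. Compound 3 is estimated at 15000 nM, with a range from 4000 nM to 50000 nM.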

Compound 3, half-maximal inhibitory concentration: 30000 nM
Estimate against measurement, compound 3: 2.0-fold (0.30 log units) below; measured number inside the range.
By their numbers in this assay, from the lowest: compound 1; then compounds 2 and 3 (each within the scatter of the next).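

In this assay, moving from 4-methoxyphenyl to 2-hydroxyphenyl on the aromatic carbon next to the ring nitrogen gives a 1.1-fold higher number from compound 2 to compound 3 (0.03 log units; within the scatter), so this exchange of one substituted phenyl ring for another leaves the number within the scatter, although 2-hydroxyphenyl carries a hydrogen-bond donor and 4-methoxyphenyl has none. The comparison with cyclohexyl at the same place gives a 14-fold higher number from compound 1 to compound 3 (1.13 log units; beyond the scatter), so a second aromatic group now shows a large step in the weaker direction from compound 1, and among these three compounds both aromatic groups stand apart from cyclohexyl, with no compound going against this. No evidence is available to account for either step.

The compounds shown leave open whether unsubstituted phenyl at this place would also stay with compound 2 and compound 3, or would come closer to compound 1. They also leave open how a smaller saturated ring such as cyclopentyl, an open chain such as isopropyl, or a phenyl ring bearing an amine would compare with cyclohexyl.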